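The source may hold more compounds than are shown below. What is called first, only, known or untested is meant among the compounds shown, and "the series" means these compounds.

In a functional assay on SH-SY5Y cells (Homo sapiens) for antiproliferative activity, read by MTT assay, with a stated time of 72 h (a lower number here means a stronger inhibitor, a higher number a weaker inhibitor), compound 1 (`c1ccc(COc2ccccc2Nc2ncnc3cc4c(cc23)OCCOCCO4)cc1`) gives 93700 nM and compound 2 (`O=[N+]([O-])c1ccc(COc2ccc(Nc3ncnc4cc5c(cc34)OCCOCCO5)cc2)cc1`) gives 55200 nM, two values within the scatter of each other. Compound 3 (`FC(F)(F)c1ccc(COc2ccc(Nc3ncnc4cc5c(cc34)OCCOCCOCCO5)cc2)cc1`) returns no number, only a limit of the assay, > 100000 nM.

Compound 4 (`FC(F)(F)c1ccc(COc2ccccc2Nc2ncnc3cc4c(cc23)OCCOCCO4)cc1`) keeps the core of compound 1 but has trifluoromethyl in place of hydrogen on an aromatic carbon, para to a large group, which turns benzyloxy into (4-(trifluoromethyl)benzyl)oxy: trifluoromethyl in place of hydrogen on an aromatic carbon. Among the measured compounds shown here, compound 3 carries this same group but also differs from compound 1 elsewhere, so no measured pair isolates the change.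

In this assay, little movement is therefore expected, with nothing beyond the scatter or at most a slight shift towards a higher number. This expectation leans on compound 2, which has a substituted benzyl group and stays at 55200 nM. The expected size of the change is a 1.2-fold lower number from compound 1 to compound 4 (0.07 log units; within the scatter). For compound 4 the estimate is 80000 nM, with an expected range from 35000 nM to 150000 nM.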

Compound 4, half-maximal inhibitory concentration: > 100000 nM
Compound 4: only a limit was reported (the forecaster's own chance of this, stated with the estimate: 35%); middle value at least 1.2-fold (0.09 log units) away from the limit.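

In this assay, compound 4 gives > 100000 nM, which is a limit of the assay and not a number. Trifluoromethyl in place of hydrogen on an aromatic carbon, para to a large group, is now the single difference in a measured pair, and the step reads an at least 1.0-fold higher number from compound 1 to compound 4 (0.02 log units; that floor lies within the scatter). This change to the benzyloxy group of compound 1 therefore gives no sign of a lower number, but how far the true step runs past that floor cannot be read, as the result sits at the assay's limit: the limit of > 100000 nM in this assay, at which 2 of the 4 values shown sit.

The compounds shown leave open whether an amine or a methoxy group at this same place would give a measurable number. They also leave open how nitro, carried by compound 2, would read on the otherwise unchanged structure of compound 1.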